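One Chlorine Fewer on the Aryl Ring

A few compounds are considered here, and "the series" means these few. Any claim that something is new, unique, unknown or untested is made for them only; others in the source may bear on it.

Measured compounds:
compound 1, `NC1=NC2(CCSCC2)N(OCCCOc2ccc(Cl)c(Cl)c2)C(N)=N1` — 88.4%
compound 2, `NC1=NC2(CCOCC2)N(OCCCOc2ccccc2Cl)C(N)=N1` — 83.3%

Of the compounds shown here, two have been measured so far. In an assay on isolated protein for inhibition of Dihydrofolate reductase (Homo sapiens), read by spectrophotometry, using NADPH, with stated times of 5 s and 6 min, tested at 5 uM (on this read-out higher numbers stand for a stronger effect at the one concentration tested and lower numbers for a weaker effect), compound 1 gives 88.4%. Compound 2, which carries a different ring in the core and a different chlorine pattern on its aryl group, gives 83.3%. Compound 1 holds the higher of the two numbers, but the gap between them lies within the usual scatter of this kind of measurement, so the two compounds cannot be placed in any order on these data.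

Compound 3, `NC1=NC2(CCSCC2)N(OCCCOc2ccc(Cl)cc2)C(N)=N1`, is not yet measured. It differs from compound 1 in one place: hydrogen in place of chloro on an aromatic carbon. Among the measured compounds shown here, no step between two measured compounds that differ in only one place is available, so the effect of this change has to be judged from the single pair alone. The expectation is a small step downward, of a size that stays within the scatter, with a weaker effect rather than a stronger one the more likely direction. For compound 3 the expected value in this assay is 82%, within a range of 65% to 92%, which corresponds to an expected step of a number 6.4 percentage points lower from compound 1 to compound 3 (within the scatter).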

Compound 3, a percentage reported as inhibition, at one concentration (the size of the read-out at that concentration, not a potency): > 90%
Compound 3: only a limit was reported; the forecaster's own chance of this, stated with the estimate: 2%; middle value at least 8 percentage points away from the limit.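

In this assay compound 3 gives > 90%, which is a limit of the assay and not a number. Going from 3,4-dichlorophenyl to 4-chlorophenyl, with hydrogen in place of chloro on an aromatic carbon ortho to a chloro group, gives a number at least 1.6 percentage points higher from compound 1 to compound 3 (that floor lies within the scatter), so on this core the read-out at the one concentration tested does not depend on that chloro group, a point the two earlier compounds could not show. The step has a floor and no upper end, and that floor does not separate the two compounds beyond the usual scatter, so its true size stays unknown: the limit of > 90% in this assay, at which 1 of the 3 values shown sits.

The compounds shown leave open whether the remaining chloro group can also give way to hydrogen, and what a fluoro, methyl or methoxy group would do at the aromatic carbon that now carries hydrogen. They also leave open how compound 1 and compound 3 would rank in potency, since a reading at a single concentration that ends at a limit gives no potency for compound 3.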